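This account rests on a few compounds, and the source may have more. Where it says the series, first, only, none or still open, it means among the compounds named here.

Measured so far:
compound 1 `Cc1c(OCCCCOCOc2ccc(C(=O)O)cc2)ccc(C(=O)CC2CCCC2)c1O` gives 228 nM in an assay on HEK293 cells for positive allosteric modulation of metabotropic glutamate receptor 2 (Rattus norvegicus), read by thallium flux, with a stated time of 2.5 min; a higher number here means that more compound is needed for the effect, a lower number that less compound is needed;
compound 2 `COc1cc(C(=O)O)ccc1OCCCCOc1ccc(C(=O)CC(C)C)c(O)c1C` gives 40 nM in this assay.

Compound 1 stands as the highest of the two numbers; the nearest is compound 2, whose number is lower by a gap beyond the scatter. Compound 3 `COc1ccc(C(=O)O)cc1OCCCCOc1ccc(C(=O)CC2CCCC2)c(O)c1C` has the same atoms as compound 1, joined differently: 5-carboxy-2-methoxyphenyl in place of (4-carboxyphenoxy)methyl on an oxygen on a saturated carbon. Among the compounds with values here, no step between measured compounds matches this change. Compound 3 carries a methoxy-bearing carboxyphenyl joined directly to the chain oxygen, as does compound 2 with its value of 40 nM, while it keeps the ketone side of compound 1. The step is therefore expected to be downward, beyond the scatter, though the carboxyl and methoxy sit on different ring positions from those of compound 2. Compound 3 is estimated at 70 nM, within 25 nM to 200 nM, an expected step of a 3.3-fold lower number from compound 1 to compound 3 (0.51 log units; beyond the scatter).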

Compound 3, half-maximal effective concentration: 425 nM
Compound 3: the middle estimate sits 6.1-fold (0.78 log units) below what was measured; measured number above the stated range.
By their numbers in this assay, from the lowest: compound 2; then compounds 1 and 3 (each within the scatter of the next).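

In this assay, 5-carboxy-2-methoxyphenyl in place of (4-carboxyphenoxy)methyl on an oxygen on a saturated carbon gives a 1.9-fold higher number from compound 1 to compound 3 (0.27 log units; within the scatter). The two arrangements of the same atoms therefore cannot be told apart at this position, with the ketone side of compound 1 held constant. Nothing available here explains this result.

Compound 2, at 40 nM, differs from compound 3 in both its ketone side and the ring on the chain oxygen, so the compounds shown do not settle which of these places accounts for its value. Also open, from the compounds shown here alone, is how this position would respond to an amide in place of the carboxylic acid, or to a longer linking chain.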